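Methoxy on the Anilino Ring of a Thiazole Amide

The compounds below may be only part of what the source reports. "The series", "measured", "known", "first", "only" and "open" are said of these compounds alone.

Compound 1 `Cc1nc(SCC(=O)Nc2nc(-c3ccc(Cl)cc3)cs2)n(Nc2ccccc2)c1C`: 7730 nM
Compound 2 `Cc1ccc(Nn2c(SCC(=O)Nc3nc(-c4ccccc4)cs3)nc(C)c2C)cc1`: > 100000 nM

Within the data shown here, in a functional assay on OVCAR-8 cells (Homo sapiens) for antiproliferative activity, read by sulforhodamine B assay, with a stated time of 48 h (on this read-out higher numbers stand for weaker inhibition of growth and lower numbers for stronger inhibition of growth), compound 1 gives 7730 nM, the only number obtained. For compound 2 the assay reports a limit only, > 100000 nM. Among the measured compounds shown here, compound 2 differs from compound 1 in two places at once, so their values show only that this combined change loses the measurable inhibition seen with compound 1, compound 2 sitting at the limit of > 100000 nM in this assay, at which 1 of the 2 values shown sits.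

Compound 3 `COc1ccc(Nn2c(SCC(=O)Nc3nc(-c4ccc(Cl)cc4)cs3)nc(C)c2C)cc1` differs from compound 1 in one place: methoxy in place of hydrogen on an aromatic carbon. For the measured compounds named here, no single-change step has been measured, so the expectation rests on the two values shown. A modest step toward weaker inhibition from compound 1 to compound 3 is expected, a 1.9-fold higher number from compound 1 to compound 3 (0.29 log units; within the scatter), extending beyond the scatter. Compound 3 is estimated at 15000 nM, ranging from 5000 nM to 80000 nM.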

Compound 3, concentration for total growth inhibition: > 100000 nM
Compound 3 gave a limit, no number (the forecaster's own chance of this, stated with the estimate: 25%); at least 6.6-fold (0.82 log units) between middle value and limit.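

In this assay, changing anilino to (4-methoxyphenyl)amino, with the methoxy para to a large group, gives an at least 12-fold higher number from compound 1 to compound 3 (1.11 log units; beyond the scatter). This single change on the anilino ring is enough to lose the measurable inhibition of compound 1. The value of compound 3 is a limit, not a number, and it is a limit shared with another compound: the limit of > 100000 nM in this assay, at which 2 of the 3 values shown sit.

On these data alone, how far the true value of compound 3 lies from that limit stays open. So does whether a fluorine or an amine on the same carbon would keep a measurable value.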